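The source may report more compounds than this note shows. Statements on the series, on what has been measured and on what is new or still open speak of the compounds shown alone.

Measured in a functional assay on K562 cells (Homo sapiens), read by MTT assay, with a stated time of 72 h; a lower number here means a stronger inhibitor, a higher number a weaker inhibitor:
- Compound 1 `CN(C)c1ncnc2c1c(-c1cc3ccccc3o1)cn2[C@@H]1O[C@H](CO)[C@@H](O)[C@H]1O`: > 20000 nM
- Compound 2 `Cc1ncnc2c1c(-c1ccoc1)cn2[C@@H]1O[C@H](CO)[C@@H](O)[C@H]1O`: > 20000 nM

Both entries are limits of the assay, not numbers, so the picture so far is simply (the limit of > 20000 nM in this assay, at which 2 of the 2 values shown sit). Compound 2 reads > 20000 nM, which is a limit. No true potency can be read from it, and it offers no firm starting point for a comparison.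

Compound 3 `Cc1ncnc2c1c(-c1cc3ccccc3o1)cn2[C@@H]1O[C@H](CO)[C@@H](O)[C@H]1O` follows from compound 2 by one change, 1-benzofuran-2-yl in place of furan-3-yl on an aromatic carbon. Compound 1 carries that same 1-benzofuran-2-yl group, and its reading of > 20000 nM is also a limit.

Among the compounds with values here, no measured step shows what this swap does in this assay, so no change beyond the scatter is expected, and another limit is the likeliest result. The expected step of a number no higher from compound 2 to compound 3 (the limit leaves the size open) is therefore no more than an estimate. For compound 3 the estimated value is 20000 nM, with an expected range of 6000 nM to 40000 nM.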

Compound 3, half-maximal inhibitory concentration: > 20000 nM
Compound 3: a limit, no number; the forecaster's own chance of this, stated with the estimate: 80%; the middle value lies on the limit itself.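

In this assay compound 3 gives > 20000 nM, which is a limit and not a number. Within the data shown here, no step from compound 1 or compound 2 to compound 3 can therefore be read. The compounds shown leave open how strong each one truly is and whether either swap changes that: the limit of > 20000 nM in this assay, at which 3 of the 3 values shown sit.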